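Growing the Ring on the Aromatic Nitrogen

The compounds below may be only part of what the source reports. "The series", "measured", "known", "first", "only" and "open" are said of these compounds alone.

Two measured compounds share one core and differ only in the aromatic group on an aromatic nitrogen. Compound 1 `O[C@H](COCCOC[C@@H](O)Cc1cn(-c2cncnc2)nn1)Cc1ccc(-c2ccccc2)cc1` gives in a functional assay on SGC-7901 cells (Homo sapiens) for inhibition, read by MTT assay, with a stated time of 72 h (a lower number here means a stronger inhibitor of growth, a higher number a weaker inhibitor of growth), only a limit, > 100000 nM. Within the data shown here, compound 2 `O[C@H](COCCOC[C@@H](O)Cc1cn(-c2cccnc2)nn1)Cc1ccc(-c2ccccc2)cc1` gives 29800 nM, the single real number so far. Among the measured compounds shown here, the only measured step, an at least 3.3-fold lower number from compound 1 to compound 2 (0.52 log units; beyond the scatter), concerns a different exchange than the one now considered, so it offers limited guidance. Compound 3 `O[C@H](COCCOC[C@@H](O)Cc1cn(-c2cncc3ccccc23)nn1)Cc1ccc(-c2ccccc2)cc1` carries the change (isoquinolin-4-yl in place of pyridin-3-yl on an aromatic nitrogen). Compound 3 is expected near 15000 nM, between 4000 nM and 60000 nM. The expected step of a 2.0-fold lower number from compound 2 to compound 3 (0.30 log units; within the scatter) is therefore small, within the scatter.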

Compound 3, concentration for 50% growth inhibition: 29300 nM
Estimate against measurement, compound 3: 2.0-fold (0.29 log units) below; the range from low to high includes it.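

The added six-membered aromatic ring of carbon only in isoquinolin-4-yl does not separate the two compounds in this assay, so this position accepts the larger group with no readable gain or loss: a 1.0-fold lower number from compound 2 to compound 3 (0.01 log units; within the scatter). Isoquinolin-4-yl also stands apart from pyrimidin-5-yl, much as pyridin-3-yl does: an at least 3.4-fold lower number from compound 1 to compound 3 (0.53 log units; beyond the scatter). That step has no exact size, since compound 1 is known only through a limit of the assay: the limit of > 100000 nM in this assay, at which 1 of the 3 values shown sits.

Open, on these data alone, is whether an amine or a carboxylic acid on pyridin-3-yl would move the number at this position.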